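The source may hold more compounds than are shown below. What is called first, only, known or untested is meant among the compounds shown, and "the series" means these compounds.

Compound 1 `O=C(CCl)Nc1ccc(SCC(=O)Nc2ccc(Cl)cn2)cc1` in a functional assay on NCI-H460 cells (Homo sapiens) for antiproliferative activity, read by MTT assay, with a stated time of 48 h (on this read-out lower numbers stand for stronger inhibition and higher numbers for weaker inhibition), gives 420 nM.
Compound 2 `O=C(CCl)Nc1ccc(SCC(=O)Nc2ccc(Br)cn2)cc1` gives 530 nM.
Compound 3 `O=C(CCl)Nc1ccc(SCC(=O)Nc2cccc(Cl)c2)cc1` gives 33400 nM.

Compound 1 has the lowest number of the three, although the step of a 1.3-fold higher number from compound 1 to compound 2 (0.10 log units; within the scatter) lies within the scatter, so compound 1 and compound 2 cannot be ranked against each other. The steps of an 80-fold higher number from compound 1 to compound 3 (1.90 log units; beyond the scatter) and a 63-fold higher number from compound 2 to compound 3 (1.80 log units; beyond the scatter) are large. Compound 4 `O=C(CSc1ccc(NC(=O)C(Cl)(Cl)Cl)cc1)Nc1ccc(Cl)cn1` differs from compound 1 in one place: trichloromethyl in place of chloromethyl on a carbonyl carbon. Within the data shown here, none of the measured steps touches this part of the molecule; they all concern the halogen or the ring on the amide-type nitrogen at the other end. Among the measured compounds shown here, no size of step in this assay can therefore be read from them, and the most cautious expectation is a step of a 1.4-fold higher number from compound 1 to compound 4 (0.15 log units; within the scatter) that stays within the scatter. Compound 4 is expected at 600 nM, with a range from 150 nM to 2500 nM.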

Compound 4, half-maximal inhibitory concentration: > 80000 nM
Compound 4: only a limit was reported (the forecaster's own chance of this, stated with the estimate: 3%); middle value at least 130-fold (2.12 log units) from the limit.
By their numbers in this assay, from the lowest: compounds 1 and 2 (each within the scatter of the next); then compound 3. At a limit, above all of these: compound 4.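

Compound 4 stands at > 80000 nM in this assay and this value is a limit of the assay, not a number. Trichloromethyl in place of chloromethyl on the carbonyl carbon gives a step of an at least 190-fold higher number from compound 1 to compound 4 (2.27 log units; beyond the scatter) and this step is large. The earlier compounds shown here all carry chloromethyl here, so only now does this end of the molecule prove sensitive to change.

Only these two groups are shown at this place, so it stays open how a plain methyl or a dichloromethyl group would read. Also open, as far as these compounds go, is whether the same change acts alike in compounds with 3-chlorophenyl on the other amide nitrogen.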